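The compounds below may be only part of what the source reports. "The series", "measured", "known", "first", "only" and "open" are said of these compounds alone.

Series notes, 5-hydroxytryptamine receptor 6 agonism. Compound 1 `O=S(=O)(c1cccc(F)c1)c1cn(C2CCNC2)c2ncccc12` is measured in a functional assay on HeLa cells for agonist activity at 5-hydroxytryptamine receptor 6 (Homo sapiens), read by cAMP accumulation and immunoassay (a higher number here means that more compound is needed for the effect, a lower number that less compound is needed), where compound 1 gives 278 nM. Compound 2 `CN1CCC(n2cc(S(=O)(=O)c3cccc(F)c3)c3cccnc32)C1` carries methyl in place of hydrogen on an amine nitrogen in a ring; in this assay compound 2 gives 231 nM, so the methylation made a 1.2-fold lower number from compound 1 to compound 2 (0.08 log units; within the scatter). Compound 3 `O=S(=O)(c1cc(Cl)cc(Cl)c1)c1cn(C2CCCNC2)c2ncccc12` has a different core from compound 1; the difference between the two cores is not broken down here. In this assay compound 3 gives 297 nM, which lies within the scatter of both compound 1 and compound 2.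

Compound 4 `CN1CCCC(n2cc(S(=O)(=O)c3cc(Cl)cc(Cl)c3)c3cccnc32)C1` is not yet measured. It differs from compound 3 by methyl in place of hydrogen on an amine nitrogen in a ring. Going by the values given here, this is the same kind of change as the one from compound 1 to compound 2, with the surroundings differing: in compound 2 the amine nitrogen sits in a five-membered non-aromatic ring with 1 nitrogen, in compound 4 in a six-membered non-aromatic ring with 1 nitrogen, in each case two ring bonds from the ring atom that bears a large group.

The step from compound 3 to compound 4 in this assay is expected to be a 1.2-fold lower number from compound 3 to compound 4 (0.07 log units; within the scatter), resting on one pair only, because a 1.2-fold lower number from compound 1 to compound 2 (0.08 log units; within the scatter) was within the scatter. Compound 4 is thus estimated at 250 nM, between 120 nM and 520 nM.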

Compound 4, half-maximal effective concentration: 38.7 nM
Beside the measured number, compound 4's estimate is 6.5-fold (0.81 log units) above it; the measured number lies below the stated range.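

In this assay, going from piperidin-3-yl to 1-methylpiperidin-3-yl gives a 7.7-fold lower number from compound 3 to compound 4 (0.89 log units; beyond the scatter). The size of this methylation step therefore does not carry unchanged from one core to another in this series: the same change on two cores in this assay, a 1.2-fold lower number (0.08 log units; within the scatter) from compound 1 to compound 2 and a 7.7-fold lower number (0.89 log units; beyond the scatter) from compound 3 to compound 4, 6.4-fold (0.80 log units) apart, beyond the scatter of two such steps

This does not show which feature of the core sets the size of the step, as the two pairs differ both in the size of the amine ring and in the halogens on the other aromatic ring, and a single pair on each core cannot separate these differences.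

Left open is how the same methylation behaves where only one of these features changes, such as on the six-membered ring combined with the fluorine of compound 1, or on the five-membered ring combined with the two chlorines of compound 3. Also open, from the compounds shown here alone, is whether an ethyl group or a longer chain on the same nitrogen would follow the step seen with methyl on the core of compound 3.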